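The source may hold more compounds than are shown below. What is called first, only, known or untested is meant among the compounds shown, and "the series" means these compounds.

Of the compounds shown here, three with a shared core have been measured in a toxicity assay on HEK-293T cells (Homo sapiens) for cytotoxicity, read by MTT assay, with a stated time of 72 h; on this read-out lower numbers stand for stronger inhibition and higher numbers for weaker inhibition. Compound 1 `CN(C)CCCCCn1c2c(c3ccccc31)C(=O)c1c[n+]([O-])c3ccccc3c1C2=O` gives 70 nM, compound 2 `O=C1c2c[n+]([O-])c3ccccc3c2C(=O)c2c1c1ccccc1n2Cc1cn([C@@H]2C[C@H](O)[C@@H](CO)O2)nn1` gives 820 nM, and compound 3 `CN1CCN(CCCCCCn2c3c(c4ccccc42)C(=O)c2c[n+]([O-])c4ccccc4c2C3=O)CC1` gives 5800 nM, the highest number of the three. Compound 4 `O=C1c2c[n+]([O-])c3ccccc3c2C(=O)c2c1c1ccccc1n2Cc1cn(C[C@@H](O)CO)nn1` differs from compound 3 in one place: 1-(2,3-dihydroxypropyl)-1H-1,2,3-triazol-4-yl in place of 5-(4-methylpiperazin-1-yl)pentyl on a saturated chain carbon bound to an aromatic nitrogen.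

For the measured compounds named here, the only measured single-place step is an 83-fold higher number from compound 1 to compound 3 (1.92 log units; beyond the scatter). It is large, so a change in the side chain can shift this number strongly, but it involves no 1H-1,2,3-triazol-4-yl group and gives no direct measure for this change. Compound 2 is the closer guide, since it also carries a 1H-1,2,3-triazol-4-yl group, with a different substituent on it, and gives 820 nM. This rests on one compound, so the expectation is loose. A move to a lower number, beyond the scatter, is expected, with the estimated step being a 5.8-fold lower number from compound 3 to compound 4 (0.76 log units; beyond the scatter). For compound 4 the estimated value is 1000 nM, with an expected range of 300 nM to 3500 nM.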

Compound 4, half-maximal inhibitory concentration: 2030 nM
The estimate for compound 4 lay 2.0-fold (0.31 log units) below the measured number, within the range that was stated.
By their numbers in this assay, from the lowest: compound 1; then compound 2; then compound 4; then compound 3.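

In this assay, for the compounds shown here, placing the 1-(2,3-dihydroxypropyl)-1H-1,2,3-triazol-4-yl group on the saturated chain carbon bound to an aromatic nitrogen gives a modest shift (a 2.9-fold lower number from compound 3 to compound 4 (0.46 log units; beyond the scatter)), a first direct reading for a side chain of this kind against the piperazine one. Keeping the triazole and changing only its substituent, 2,3-dihydroxypropyl in place of 4-hydroxy-5-(hydroxymethyl)oxolan-2-yl, also moves the number modestly (a 2.5-fold higher number from compound 2 to compound 4 (0.39 log units; beyond the scatter)), so the group on the triazole nitrogen has a measurable influence. The change relative to the 4-(dimethylamino)butyl chain is much larger (a 29-fold higher number from compound 1 to compound 4 (1.46 log units; beyond the scatter)), and so the choice of side chain at this position can matter far more than the substituent on the triazole.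

On these data alone, how a carboxylic acid or a longer chain on the triazole would read remains open. No measurement here explains any of these steps.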